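Replacing the Amide Substituent of Compound 2

The source may report more compounds than this note shows. Statements on the series, on what has been measured and on what is new or still open speak of the compounds shown alone.

Values in a functional assay on MCF7 cells (Homo sapiens) for antiproliferative activity, read by MTT assay, with a stated time of 72 h; on this read-out higher numbers stand for weaker inhibition and lower numbers for stronger inhibition
- Compound 1 `CCn1cc(C(CC)(CC)c2ccc(C#CC(O)(CC)CC)c(C)c2)cc1C(=O)NCCN(C)C` gives 13400 nM
- Compound 2 `CCn1cc(C(CC)(CC)c2ccc(C#CC(O)(CC)CC)c(C)c2)cc1C(=O)NCC(=O)O` gives 17500 nM

Among the compounds with values here, compound 2 stands at 17500 nM in this assay and lies within the scatter of compound 1, the only other measured compound. Compound 3 `CCn1cc(C(CC)(CC)c2ccc(C#CC(O)(CC)CC)c(C)c2)cc1C(=O)N[C@@H](C)CO` has not yet been measured. Its difference from compound 2 is 1-(hydroxymethyl)ethyl in place of carboxymethyl on an amide-type nitrogen and amounts to 1-(hydroxymethyl)ethyl in place of carboxymethyl on an amide-type nitrogen. Within the data shown here, one measured step bears on this: a 1.3-fold higher number from compound 1 to compound 2 (0.12 log units; within the scatter) for carboxy in place of (dimethylamino)methyl on a saturated chain carbon bound to an amide-type nitrogen. Among the measured compounds shown here, that step stayed within the scatter, but it is the only guide, and no measured compound carries 1-(hydroxymethyl)ethyl. No shift beyond the scatter is therefore expected in this assay, with an estimated step of a 1.2-fold lower number from compound 2 to compound 3 (0.07 log units; within the scatter) and no firm direction. For compound 3 the estimated value is 15000 nM with an expected range from 7000 nM to 32000 nM at this stage.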

Compound 3, half-maximal inhibitory concentration: 1910 nM
The estimate for compound 3 lay 7.9-fold (0.90 log units) above the measured number; the measured number lies below the stated range.
By their numbers in this assay, from the lowest: compound 3; then compounds 1 and 2 (each within the scatter of the next).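

In this assay the group on the amide-type nitrogen proved able to move the number beyond the scatter, which the earlier pair did not show: exchanging carboxymethyl for 1-(hydroxymethyl)ethyl gave a 9.2-fold lower number from compound 2 to compound 3 (0.96 log units; beyond the scatter) and exchanging 2-(dimethylamino)ethyl for the same group gave a 7.0-fold lower number from compound 1 to compound 3 (0.85 log units; beyond the scatter) in the same direction. The lower number for compound 3 therefore holds whether the group it replaces ends in a carboxylic acid or in a dimethylamino group. Nothing measured here accounts for this change.

On these data alone, it remains open whether the hydroxyl, the branching methyl or the defined stereocentre of 1-(hydroxymethyl)ethyl goes with the lower number. As far as these compounds go, an unbranched 2-hydroxyethyl group, the opposite enantiomer or a methyl ether on that oxygen could separate these, and the effect of a longer chain also remains open.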